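This account rests on a few compounds, and the source may have more. Where it says the series, first, only, none or still open, it means among the compounds named here.

Measured compounds:
Compound 1 `Nc1nc(N)c(CCCN(Cc2ccc(NC(CCC(=O)O)C(=O)O)cc2)c2cc(F)cc(F)c2[N+](=O)[O-])c(O)n1` — in a functional assay on CCRF-CEM cells (Homo sapiens) for cytotoxicity, in the absence of a further agent (on this read-out lower numbers stand for stronger inhibition and higher numbers for weaker inhibition), compound 1 gives only a limit, > 100000 nM (the limit of > 100000 nM in this assay, at which 1 of the 3 values shown sits).
Compound 2 `COC(=O)c1ccc(CN(CCCc2c(N)nc(N)nc2O)c2cc(F)ccc2[N+](=O)[O-])cc1` — in this assay compound 2 gives 45000 nM.
Compound 3 `Nc1nc(N)c(CCCN(Cc2ccc(NC(CCC(=O)O)C(=O)O)cc2)c2cc(F)c([N+](=O)[O-])cc2[N+](=O)[O-])c(O)n1` — in this assay compound 3 gives 40000 nM.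

Compound 3 and compound 2 thus give numbers that lie within the usual scatter of each other, so neither can be set above the other; compound 1 stands apart, its value being a limit rather than a number. The step under study goes from compound 3 to compound 4 `Nc1nc(N)c(CCCN(Cc2ccc(NC(CCC(=O)O)C(=O)O)cc2)c2cc(F)ccc2[N+](=O)[O-])c(O)n1`, a single change: hydrogen in place of nitro on an aromatic carbon. Going by the values given here, no measured pair shows this same change, so the expectation rests on the three values shown alone. Compound 4 is expected to give a weaker number, a step of a 2.0-fold higher number from compound 3 to compound 4 (0.30 log units; within the scatter), and its estimated value in this assay is 80000 nM, within a range from 30000 nM to 200000 nM.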

Compound 4, half-maximal inhibitory concentration: > 100000 nM
Compound 4: only a limit was reported; the forecaster's own chance of this, stated with the estimate: 35%; at least 1.2-fold (0.09 log units) between middle value and limit.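

In this assay, going by these compounds alone, hydrogen in place of nitro gives an at least 2.5-fold higher number from compound 3 to compound 4 (0.39 log units; beyond the scatter), so at this position, ortho to a fluoro group, the change carries a real cost, which no earlier pair could show. The other change, (1,3-dicarboxypropyl)amino in place of methoxycarbonyl, gives an at least 2.2-fold higher number from compound 2 to compound 4 (0.34 log units; beyond the scatter). The step from compound 1 to compound 4 cannot be read, and limits now make up much of the set: the limit of > 100000 nM in this assay, at which 2 of the 4 values shown sit.

As far as these compounds go, whether an amine or a nitrile on this carbon would keep the number of compound 3 stays open. From the compounds shown here alone, the full size of both readable steps also stays open.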